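Cyclic sulfonamide replacements on a biphenyl core: acidity notes

This account rests on a few compounds, and the source may have more. Where it says the series, first, only, none or still open, it means among the compounds named here.

Measured so far:
compound 1 `CCc1nc2c(C)cc(C)nc2n1Cc1ccc(-c2ccccc2C2Nc3ccccc3S(=O)(=O)N2)cc1` — > 10.5
compound 2 `CCc1nc2c(C)cc(C)nc2n1Cc1ccc(-c2ccccc2C2=NS(=O)(=O)c3cc(S(N)(=O)=O)c(Cl)cc3N2)cc1` — 7

In a physicochemical assay for acid dissociation, compound 1 gives > 10.5, which is a limit of the assay and not a number. In this assay compound 2 gives 7. The two share the core, and differ in the ring system carried on the biphenyl; with only a limit for compound 1, the two values show no more than that compound 1 sits at the limit of > 10.5 in this assay, at which 1 of the 2 values shown sits, while compound 2 gives a number.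

Compound 3 `CCc1nc2c(C)cc(C)nc2n1Cc1ccc(-c2ccccc2N2N=C(c3ccccc3)N[S+]2[O-])cc1` is not yet measured. It differs from compound 1 by a group of 12 heavy atoms (7 carbon, 3 nitrogen, 1 oxygen, 1 sulfur; one five-membered non-aromatic ring with 4 hetero atoms, one six-membered aromatic ring of carbon only) in place of a group of 12 heavy atoms (7 carbon, 2 nitrogen, 2 oxygen, 1 sulfur; one six-membered non-aromatic ring with 3 hetero atoms, one six-membered aromatic ring of carbon only), on an aromatic carbon, the replacement sitting ortho to a large group.

Among the measured compounds shown here, no measured step in this assay is on hand for this kind of change. The step from compound 1 to compound 3 is expected to be downward and well beyond the scatter, the expectation being a number at least 3.50 log units lower from compound 1 to compound 3 (beyond the scatter). Compound 3 is expected to give 7 in this assay, within 5.5 to 8.5.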

Compound 3, acid dissociation constant: about 7.1
Compound 3: middle estimate off by 0.10 log units, on the low side; measured number inside the range.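

In this assay, the change on the aromatic carbon, ortho to a large group, now has a readable step: the five-membered non-aromatic ring with 4 hetero atoms, carrying its six-membered aromatic ring of carbon only, in place of the six-membered non-aromatic ring with 3 hetero atoms gives a number at least 3.40 log units lower from compound 1 to compound 3 (beyond the scatter). The size of this step is only a bound, since the value for compound 1 is a limit of the assay and not a number: the limit of > 10.5 in this assay, at which 1 of the 3 values shown sits.

Compound 2 gives 7 and compound 3 gives about 7.1, so two different groups at this place on the shared core now give values within the usual scatter of each other.

The compounds shown leave open how large the step from compound 1 really is, and whether the ring with 4 hetero atoms or the attached aromatic ring of carbon only accounts for it. They also leave open where a carboxylic acid at this same place on the aromatic carbon would fall in this assay.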